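Geometric isomer of a fluoropyridinyl-ethenyl piperidine amide

The compounds below may be only part of what the source reports. "The series", "measured", "known", "first", "only" and "open" are said of these compounds alone.

In a functional assay on isolated protein for antagonist activity at Orexin receptor type 2 (Homo sapiens), read by FLIPR and calcium flux (a lower number here means a stronger inhibitor, a higher number a weaker inhibitor), compound 3 `Cc1ccc(-n2nccn2)c(C(=O)N2C[C@H](C#Cc3cccnc3O)CC[C@H]2C)c1` gives "not determined" (no result reported); compound 2 `Cc1ccc(-n2nccn2)c(C(=O)N2C[C@H](C#Cc3ccc(CO)cn3)CC[C@H]2C)c1` likewise gives "not determined" (no result reported). Only compound 1 `Cc1ccc(-n2nccn2)c(C(=O)N2C[C@H](/C=C/c3ccc(F)cn3)CC[C@H]2C)c1` carries a value, and in this assay compound 1 gives 34 nM. Compound 4 `Cc1ccc(-n2nccn2)c(C(=O)N2C[C@H](/C=C\c3ccc(F)cn3)CC[C@H]2C)c1` differs from compound 3 by 2-(5-fluoropyridin-2-yl)ethenyl in place of 2-(2-hydroxypyridin-3-yl)ethynyl on a saturated ring carbon. Since compound 3 has no result, no size or direction can be given for the step to compound 4 in this assay. Compound 4 shares everything but the double-bond geometry with compound 1, so its potency is expected near that of compound 1 but with wide uncertainty. Compound 4 is estimated at 120 nM, ranging from 25 nM to 600 nM.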

Compound 4, half-maximal inhibitory concentration: 417 nM
Estimate against measurement, compound 4: 3.5-fold (0.54 log units) below; the range from low to high includes it.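

Going by these compounds alone, with the first comparison at this position, this assay shows that the saturated ring carbon two ring bonds from the ring nitrogen is sensitive to the geometry of the 2-(5-fluoropyridin-2-yl)ethenyl group: going from E to Z gives a 12-fold higher number from compound 1 to compound 4 (1.09 log units; beyond the scatter). The loss can be assigned to geometry alone because no other feature separates this pair: the fact that compounds 1 and 4 differ only in the configuration as drawn

Steps from compound 3 cannot be read, as it has no result, so the ethynyl link remains uncompared with either ethenyl form. As far as these compounds go, how a saturated two-carbon chain carrying the same 5-fluoropyridin-2-yl group would compare also remains open.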